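This account rests on a few compounds, and the source may have more. Where it says the series, first, only, none or still open, it means among the compounds named here.

Compound 1, `C=CCNc1nc(N)c(C(=O)N=C(N)N)nc1Cl`, gives 16% in an assay for inhibition of acid-sensing ion channel 3 (Homo sapiens), read by patch clamp, tested at 1 uM; on this read-out lower numbers stand for less inhibition and higher numbers for more inhibition at the one concentration tested (going by the name of the read-out).
Compound 2, `CC(C)(C)Nc1nc(N)c(C(=O)N=C(N)N)nc1Cl`, is reported as "not determined" (no result reported) in this assay, so no result is available for it.
Compound 3, `NC(N)=NC(=O)c1nc(Cl)c(NCC2CCCCC2)nc1N`, gives 28% in this assay.

Among the two numbers known, compound 3 stands highest in this assay. Going by the values given here, its nearest neighbour is compound 1, and the single step that connects them, a number 12 percentage points higher from compound 1 to compound 3 (beyond the scatter), is the only measured change available; it swaps one saturated side chain for another on the nitrogen attached to the shared core and moves the read-out modestly.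

Compound 4, `NC(N)=NC(=O)c1nc(Cl)c(Nc2cccc(Cl)c2)nc1N`, is the next compound, and it differs from compound 3 in one place: 3-chlorophenyl in place of cyclohexylmethyl on a nitrogen on an aromatic ring. Among the compounds with values here, no measured step replaces a saturated chain with an aromatic ring at this nitrogen, so the one step that bears on it, a number 12 percentage points higher from compound 1 to compound 3 (beyond the scatter), can only show that changing the group on this nitrogen shifts the read-out by a modest amount in this assay.

On that basis the expected step from compound 3 to compound 4, a number 3 percentage points lower from compound 3 to compound 4 (within the scatter), is small, with a wide margin in either direction. Compound 4 is estimated at 25% in this assay, with a range from 5% to 50%.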

Compound 4, a percentage reported as inhibition, at one concentration (the size of the read-out at that concentration, not a potency): 47%
Estimate against measurement, compound 4: 22 percentage points below; low and high end bracket the measured number.
By their numbers in this assay, from the lowest: compound 1; then compound 3; then compound 4.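

Going by these compounds alone, the nitrogen on the shared core now carries an aromatic ring for the first time, and replacing cyclohexylmethyl with 3-chlorophenyl gives a number 19 percentage points higher from compound 3 to compound 4 (beyond the scatter) in this assay, even though the two groups match in heavy-atom count, in having one six-membered ring and in their zero counts of hydrogen-bond donors and acceptors. Within the data shown here, the step from the allyl group is larger, a number 31 percentage points higher from compound 1 to compound 4 (beyond the scatter), so the three numbers known at this position now fall into a clear order, from allyl through cyclohexylmethyl to 3-chlorophenyl, with each gap beyond the usual scatter. Nothing available explains why the read-out rises with this change.

Two things arrive together in this change, an aromatic ring and a chlorine, so the compounds shown cannot separate their contributions; a plain phenyl group would address this, and a benzyl group would test an aromatic ring set one chain carbon away from the nitrogen. From the compounds shown here alone, it also remains open how far a methoxy group or a nitrile in place of the chlorine would move the read-out, and all these numbers describe a single concentration, not a potency.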